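This account rests on a few compounds, and the source may have more. Where it says the series, first, only, none or still open, it means among the compounds named here.

The measured compounds:
compound 1 `O=c1cc(-n2cc(CNc3ccccc3)nn2)c2cc(Br)ccc2o1`, which in a functional assay on A549 cells (Homo sapiens) for antiproliferative activity, read by MTT assay, with a stated time of 48 h (a higher number here means a weaker inhibitor, a lower number a stronger inhibitor), gives 13200 nM;
compound 2 `O=c1cc(-n2cc(COc3ccccc3)nn2)c2cc(Br)ccc2o1`, which in this assay gives 12300 nM.

Compound 2 and compound 1 give numbers that lie within the scatter of each other, so neither stands apart from the other on what has been measured. For the measured compounds named here, the single step between them, a 1.1-fold lower number from compound 1 to compound 2 (0.03 log units; within the scatter), concerns the group carried on the saturated chain carbon and does not move the number beyond the scatter.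

Compound 3 `O=c1cc(-n2cc(COc3ccccc3)nn2)c2cc(O)ccc2o1` differs from compound 2 in a different place: hydroxy in place of bromo on an aromatic carbon. Going by the values given here, no measured step touches this position of the shared core, so the one step recorded gives no guide to the size or direction of the change to expect in this assay. The expectation therefore starts from the value of compound 2 and carries a wide range. Compound 3 is expected to give about 15000 nM in this assay, with a range from 5000 nM to 45000 nM. The expected step is a 1.2-fold higher number from compound 2 to compound 3 (0.09 log units; within the scatter), which stays within the scatter.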

Compound 3, half-maximal inhibitory concentration: > 50000 nM
Compound 3 was reported as a limit; the forecaster's own chance of this, stated with the estimate: 15%; at least 3.3-fold (0.52 log units) between middle value and limit.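

In this assay, hydroxy in place of bromo on this aromatic carbon of the shared core gives an at least 4.0-fold higher number from compound 2 to compound 3 (0.60 log units; beyond the scatter). For the compounds shown here, this position, which no earlier step touched, is therefore one where a single change of group moves the number beyond the scatter, whereas the step on the saturated chain carbon, a 1.1-fold lower number from compound 1 to compound 2 (0.03 log units; within the scatter), did not. Compound 3 is recorded as a limit of the assay and not as a number, so the step gives only a minimum size and its full size stays unknown: the limit of > 50000 nM in this assay, at which 1 of the 3 values shown sits.

The compounds shown leave open whether the step follows from the loss of bromo or the arrival of hydroxy, since this one replacement changes both at once, and a methoxy group, a chlorine atom, an amine or a plain hydrogen on the same carbon would be needed to tell these apart. They also leave open whether hydroxy in place of bromo acts the same way when the saturated chain carbon carries anilino, as in compound 1, instead of phenoxy.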